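Bulkier ester on a flavone series: cytotoxicity expectation

The source may report more compounds than this note shows. Statements on the series, on what has been measured and on what is new or still open speak of the compounds shown alone.

Measured compounds:
compound 1 `CCOC(=O)COc1cc(-c2cc(=O)c3c(O)cc(OCC(=O)N4CCN(Cc5ccc(OC)c(OC)c5OC)CC4)cc3o2)ccc1OC`: > 70000 nM
compound 2 `CCOC(=O)COc1cc(-c2cc(=O)c3c(O)cc(OCC(=O)N4CCN(Cc5ccc(OC)cc5)CC4)cc3o2)ccc1OC`: "not determined" (no result reported)
compound 3 `CCOC(=O)COc1cc(-c2cc(=O)c3c(O)cc(OCC(=O)N4CCN(Cc5ccc(O)c(OC)c5OC)CC4)cc3o2)ccc1OC`: 10000 nM

The three measured compounds share one core and differ only at the outer ends. In an ADME assay on MRC5 cells (Homo sapiens) for cytotoxicity (a lower number here means a stronger inhibitor, a higher number a weaker inhibitor), compound 1 gives > 70000 nM, which is a limit of the assay and not a number (the limit of > 70000 nM in this assay, at which 1 of the 3 values shown sits). Compound 2 has no result reported in this assay, "not determined" (no result reported). Compound 3 gives 10000 nM in this assay. Within the data shown here, the single measured step, an at least 7.0-fold lower number from compound 1 to compound 3 (0.84 log units; beyond the scatter), concerns a hydrogen in place of methyl on an oxygen on an aromatic ring, a part of the molecule far from the ester.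

Compound 4 `COc1ccc(-c2cc(=O)c3c(O)cc(OCC(=O)N4CCN(Cc5ccc(OC)c(OC)c5OC)CC4)cc3o2)cc1OCC(=O)OC(C)(C)C` differs from compound 1 by tert-butyl in place of ethyl on an oxygen next to a carbonyl group. Among the measured compounds shown here, no measured step touches this ester, and the only step known, an at least 7.0-fold lower number from compound 1 to compound 3 (0.84 log units; beyond the scatter), changes a different group. There is therefore no basis for expecting a step beyond the scatter in this assay, in either direction. Compound 4 is expected to give 80000 nM in this assay, within a range of 30000 nM to 200000 nM. The estimated step that the limit leaves unreadable from compound 1 to compound 4 reflects that expectation of little change, and because compound 1 sits at the limit (the limit of > 70000 nM in this assay, at which 1 of the 3 values shown sits), compound 4 is likely to be reported only as a limit as well.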

Compound 4, half-maximal inhibitory concentration: > 140000 nM
Compound 4: only a limit was reported; the forecaster's own chance of this, stated with the estimate: 70%; middle value at least 1.7-fold (0.24 log units) from the limit.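

In this assay compound 4 gives > 140000 nM, which is a limit of the assay and not a number. Compound 1 gives > 70000 nM, also a limit. Among these compounds, no step between compound 1 and compound 4 can be read from these two limits. The compounds shown leave open whether tert-butyl in place of ethyl changes the result in this assay at all.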